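Notes on the chloro analogue of compound 1

The compounds below may be only part of what the source reports. "The series", "measured", "known", "first", "only" and "open" are said of these compounds alone.

Two numbers exist so far in an ADME assay on microsomes from liver (Homo sapiens) for metabolic stability, tested at 2.5 uM (on this read-out higher numbers stand for fast clearance and lower numbers for slow clearance), and they sit within the scatter of one another. Compound 1 `COc1cccc(-c2c(S(=O)(=O)c3ccc(C)c(F)c3)cnc3c(F)cccc23)c1` in this assay gives 4.02 mL/min. Compound 2 `COc1cccc(-c2c(S(=O)(=O)c3ccc(F)cc3)cnc3c(F)cccc23)c1` carries 4-fluorophenyl in place of 3-fluoro-4-methylphenyl on the sulfonyl sulfur, and in this assay compound 2 gives 2.23 mL/min; the step of a 1.8-fold lower number from compound 1 to compound 2 (0.26 log units; within the scatter) is within the scatter. Compound 3 `Cc1ccc(S(=O)(=O)c2cnc3c(F)cccc3c2-c2cccc(Cl)c2)cc1F` is not yet measured. From compound 1 it differs by chloro in place of methoxy on an aromatic carbon. Among the measured compounds shown here, the single measured step, a 1.8-fold lower number from compound 1 to compound 2 (0.26 log units; within the scatter), concerns the sulfonyl sulfur and not the methoxy, so it bears on the new change only loosely, and no measured pair exchanges the methoxy. With nothing in this series moving beyond the scatter, the expected step for compound 3 in this assay is a 1.0-fold lower number from compound 1 to compound 3 (0.00 log units; within the scatter). The estimate for compound 3 in this assay is 4 mL/min, with a range from 2 mL/min to 8 mL/min.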

Compound 3, intrinsic clearance in a liver preparation (reported as CLH), per the amount of preparation that the assay uses: 3.18 mL/min
Compound 3: the middle estimate sits 1.3-fold (0.10 log units) above what was measured; low and high end bracket the measured number.
By their numbers in this assay, from the lowest: compounds 2, 3 and 1 (each within the scatter of the next).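

In this assay, among the compounds shown here, chloro in place of methoxy gives a 1.3-fold lower number from compound 1 to compound 3 (0.10 log units; within the scatter) at this aromatic carbon, the first measured step at this position rather than on the sulfonyl sulfur. In this pair, 3-chlorophenyl can therefore stand in for 3-methoxyphenyl, losing the oxygen and its hydrogen-bond acceptor, without the read-out moving beyond the scatter. No measurement available here explains why the read-out holds.

On these data alone, whether an amine or a carboxylic acid on this aromatic carbon would move the read-out beyond the scatter stays open. Also open, as far as these compounds go, is whether chloro in place of methoxy would read the same with the 4-fluorophenyl of compound 2 on the sulfonyl sulfur, since this single pair carries only the 3-fluoro-4-methylphenyl group.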